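The source may hold more compounds than are shown below. What is called first, only, known or untested is meant among the compounds shown, and "the series" means these compounds.

Working notes on the series. Compound 1 `FC(F)(F)c1ccccc1-c1nc(NCc2ccc(Cl)c(Cl)c2)c2ccccc2n1` sets the reference: in an assay on a protein complex for inhibition of ubiquitin carboxyl-terminal hydrolase 1/WD repeat-containing protein 48 (Homo sapiens), read by fluorescence (on this read-out lower numbers stand for stronger inhibition and higher numbers for weaker inhibition), compound 1 gives 10400 nM. Compound 2 `FC(F)(F)c1cccc(-c2nc(NCc3ccc(-c4cccnc4)cc3)c3ccccc3n2)c1` carries the 3-(trifluoromethyl)phenyl group and the pyridinyl-bearing benzylamine; in this assay compound 2 is reported as "not active" (no number reported), so it stands with no single number and any comparison to compound 1 is only qualitative. Compound 3 `CC(C)c1ccccc1-c1nc(NCc2ccc(-c3cccnc3)cc2)c2ccccc2n1` is the next step: 2-isopropylphenyl in place of 3-(trifluoromethyl)phenyl on an aromatic carbon. With no measured step of this kind in the set, the direction is open; a move toward weak measurable inhibition is plausible but modest. Compound 3 is expected at about 15000 nM, range 3000 nM to 60000 nM, with a real chance that only a limit is reported.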

Compound 3, half-maximal inhibitory concentration: 180 nM
For compound 3 the middle estimate is 83-fold (1.92 log units) above the measured one, outside the stated range (below it).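

No step can be read between compound 2 and compound 3, as compound 2 has no single number. The compounds shown leave open what the 2-isopropylphenyl group contributes on its own. Nothing at hand bears on this result.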